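The source may hold more compounds than are shown below. What is called first, only, known or untested is meant among the compounds shown, and "the series" means these compounds.

Three compounds sharing one core were tested in an assay for inhibition of 6-phosphofructo-2-kinase/fructose-2,6-bisphosphatase 3 (Homo sapiens), read by ADP-Glo, with a stated time of 2 h; on this read-out higher numbers stand for weaker inhibition and lower numbers for stronger inhibition. Compound 1 `CN1CCC(NC(=O)c2ccncc2Nc2cc(-c3ccc4ccn(C)c4c3)c3nccnc3c2)CC1` gives 38 nM. Compound 2 `Cn1ccc2ccc(-c3cc(Nc4cnccc4C(=O)NCC4COCCN4)cc4nccnc34)cc21` gives 33 nM. Compound 3 `CN1CCC(N(C)C(=O)c2ccncc2Nc2cc(-c3ccc4ccn(C)c4c3)c3nccnc3c2)C1` gives 176 nM, the highest of the three numbers, a modest distance beyond the scatter from both others. The steps of a 4.6-fold higher number from compound 1 to compound 3 (0.67 log units; beyond the scatter) and a 5.3-fold higher number from compound 2 to compound 3 (0.73 log units; beyond the scatter) both accompany a change that puts a methyl on the amide-type nitrogen and moves to a five-membered ring. Compound 4 `CC(=O)N1CCC(NC(=O)c2ccncc2Nc2cc(-c3ccc4ccn(C)c4c3)c3nccnc3c2)C1` differs from compound 3 by (1-acetylpyrrolidin-3-yl)amino in place of methyl(1-methylpyrrolidin-3-yl)amino on a carbonyl carbon, so the amide-type nitrogen again carries a hydrogen, as in compounds 1 and 2. On the strength of a 4.6-fold higher number from compound 1 to compound 3 (0.67 log units; beyond the scatter) and a 5.3-fold higher number from compound 2 to compound 3 (0.73 log units; beyond the scatter), the expected step is a 3.2-fold lower number from compound 3 to compound 4 (0.51 log units; beyond the scatter), a lower number. Compound 4 is therefore estimated at 55 nM, within 20 nM to 160 nM.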

Compound 4, half-maximal inhibitory concentration: 105 nM
For compound 4 the middle estimate is 1.9-fold (0.28 log units) below the measured one; the range from low to high includes it.
By their numbers in this assay, from the lowest: compounds 2 and 1 (each within the scatter of the next); then compounds 4 and 3 (each within the scatter of the next).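

In this assay the step of a 1.7-fold lower number from compound 3 to compound 4 (0.22 log units; within the scatter) brings back the amide hydrogen and replaces the ring methyl with acetyl, yet it stays within the scatter. The amide hydrogen alone therefore does not bring the number level with the other two compounds, as a 2.8-fold higher number from compound 1 to compound 4 (0.44 log units; beyond the scatter) and a 3.2-fold higher number from compound 2 to compound 4 (0.50 log units; beyond the scatter) show even with that hydrogen present. No measurement shown explains these steps. Still open, going by these compounds, is how 1-methylpyrrolidin-3-yl or 1-acetylpiperidin-4-yl would behave on the amide nitrogen with its hydrogen kept, which would separate the ring size from the acetyl group.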